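Swapping a fluoro for a nitro on the amide-side ring

This account rests on a few compounds, and the source may have more. Where it says the series, first, only, none or still open, it means among the compounds named here.

Measured compounds:
compound 1 `COc1ccc(NC(=O)CS(=O)(=O)c2nccc(Oc3c(C)cc(C#N)cc3C)n2)cc1`: 5110 nM
compound 2 `Cc1cc(C#N)cc(C)c1Oc1ccnc(S(=O)(=O)CC(=O)Nc2cccc(F)c2)n1`: 25900 nM
compound 3 `Cc1cc(C#N)cc(C)c1Oc1ccnc(S(=O)(=O)CC(=O)Nc2ccc(F)cc2)n1`: 26100 nM

In an ADME assay on MT4 cells (Homo sapiens) for cytotoxicity, read by MTT assay, with a stated time of 4 days (on this read-out lower numbers stand for higher toxicity in this test and higher numbers for lower toxicity in this test), compound 3 gives the highest of the three numbers, within the scatter of compound 2 and a 5.1-fold higher number from compound 1 to compound 3 (0.71 log units; beyond the scatter). Compound 4 `Cc1cc(C#N)cc(C)c1Oc1ccnc(S(=O)(=O)CC(=O)Nc2ccc([N+](=O)[O-])cc2)n1` differs from compound 3 only in the group on the amide-side ring: nitro in place of fluoro on an aromatic carbon. Within the data shown here, the only measured step at that carbon is a 5.1-fold higher number from compound 1 to compound 3 (0.71 log units; beyond the scatter), and no measured compound carries a nitro, so the data give no direct guide. Compound 4 is therefore expected to stay close to compound 3, with a 1.3-fold lower number from compound 3 to compound 4 (0.12 log units; within the scatter) as the estimated step in this assay. The estimate for compound 4 is 20000 nM, with a range from 7000 nM to 50000 nM.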

Compound 4, half-maximal cytotoxic concentration: 59600 nM
Beside the measured number, compound 4's estimate is 3.0-fold (0.47 log units) below it; the measured number lies above the stated range.
By their numbers in this assay, from the lowest: compound 1; then compounds 2 and 3 (each within the scatter of the next); then compound 4.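

In this assay nitro in place of fluoro gives a 2.3-fold higher number from compound 3 to compound 4 (0.36 log units; beyond the scatter) and so shows that the number at this carbon can climb past the level of the fluoro compounds. With a 2.3-fold higher number from compound 2 to compound 4 (0.36 log units; beyond the scatter) and with a 12-fold higher number from compound 1 to compound 4 (1.07 log units; beyond the scatter) the nitro compound stands highest of the four, the least toxic in this test. Nothing measured here gives a reason for this shift.

On these data alone, whether an amine or a carboxylic acid on the same carbon would sit near nitro or near methoxy stays open. So does the effect of moving nitro elsewhere on the ring.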